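Furan-3-yl to phenyl on the shared core

A few compounds are considered here, and "the series" means these few. Any claim that something is new, unique, unknown or untested is made for them only; others in the source may bear on it.

Measured so far in a functional assay on HCT-116 cells (Homo sapiens), read by MTT assay, with a stated time of 72 h; on this read-out lower numbers stand for stronger inhibition and higher numbers for weaker inhibition:
- compound 1 (`COc1ncnc2c1c(-c1cc3ccccc3o1)cn2[C@@H]1O[C@H](CO)[C@@H](O)[C@H]1O`) gives 14500 nM
- compound 2 (`C#Cc1cn([C@@H]2O[C@H](CO)[C@@H](O)[C@H]2O)c2ncnc(OC)c12`) gives 5140 nM
- compound 3 (`CSc1ncnc2c1c(-c1ccoc1)cn2[C@@H]1O[C@H](CO)[C@@H](O)[C@H]1O`) gives 100 nM

Compound 3 has the lowest number of the three, and its gaps to compound 2 and compound 1 both lie beyond the scatter. The next structure, compound 4 (`CSc1ncnc2c1c(-c1ccccc1)cn2[C@@H]1O[C@H](CO)[C@@H](O)[C@H]1O`), carries phenyl in place of furan-3-yl on an aromatic carbon. Within the data shown here, no measured step covers this exchange. Among the measured compounds shown here, the closest evidence is the single measured step, a 2.8-fold lower number from compound 1 to compound 2 (0.45 log units; beyond the scatter), with ethynyl in place of 1-benzofuran-2-yl on an aromatic carbon. That step is modest, and it shows the compound with the aromatic group at the higher number. Compound 1 and compound 2 also differ from compound 3 elsewhere on the core, so this step transfers only loosely. For the measured compounds named here, compound 3 is the only measured compound with furan-3-yl, and it sits at the low end of the values, so a move to a higher number in this assay is expected. The expected change is an 8.0-fold higher number from compound 3 to compound 4 (0.90 log units; beyond the scatter), an estimate with wide uncertainty. For compound 4 the estimated value is 800 nM (expected range 150 nM to 5000 nM).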

Compound 4, half-maximal inhibitory concentration: > 20000 nM
Compound 4: a limit, no number (the forecaster's own chance of this, stated with the estimate: 5%); at least 25-fold (1.39 log units) between middle value and limit.
By their numbers in this assay, from the lowest: compound 3; then compound 2; then compound 1. At a limit, above all of these: compound 4.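

With the rest of the structure unchanged, one five-membered aromatic ring with 1 hetero atom gives way to one six-membered aromatic ring of carbon only, and in this assay this exchange gives an at least 200-fold higher number from compound 3 to compound 4 (2.30 log units; beyond the scatter), so the choice between these two aromatic groups at this carbon decides much of the read-out on this core. Compound 4 gives > 20000 nM, which is a limit of the assay and not a number. The only earlier step, a 2.8-fold lower number from compound 1 to compound 2 (0.45 log units; beyond the scatter), was modest and set an aromatic group against ethynyl, whereas this step compares two aromatic groups directly and is large, with its full size unreadable past the limit: the limit of > 20000 nM in this assay, at which 1 of the 4 values shown sits.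

On these data alone, it remains open whether the ring oxygen or the ring size carries this step, a question on which thiophen-3-yl or pyridin-3-yl at the same carbon would bear. Also open, as far as these compounds go, is how far the low number of compound 3 depends on its methylsulfanyl group, which an amine or a longer thioether chain in its place would test.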